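A few compounds are considered here, and "the series" means these few. Any claim that something is new, unique, unknown or untested is made for them only; others in the source may bear on it.

Three analogues built on one shared core have been tested in a functional assay on CCRF-CEM cells (Homo sapiens) for inhibition, read by MTT assay, with a stated time of 4 days; a higher number here means a weaker inhibitor, a lower number a stronger inhibitor. Compound 1, `COc1cc(NC(C)CCCNC(=O)NNC(=O)N(CCO)CCO)c2ncccc2c1`, gives in this assay only a limit of the assay, > 250000 nM. Compound 2, `COc1cc(NC(C)CCCNC(=O)NNC(=O)NCCCO)c2ncccc2c1`, likewise gives in this assay only a limit, > 250000 nM. Compound 3, `COc1cc(NC(C)CCCNC(=O)NNC(=O)NCCO)c2ncccc2c1`, also reaches in this assay no more than a limit, > 250000 nM. The steps among the three, a step that the two limits leave unreadable from compound 1 to compound 2, a step that the two limits leave unreadable from compound 1 to compound 3 and a step that the two limits leave unreadable from compound 2 to compound 3, therefore cannot be read, because of the limit of > 250000 nM in this assay, at which 3 of the 3 values shown sit. Compound 3 thus stands at the same limit as the other two, with no number to rank it against them.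

Compound 4, `COc1cc(NC(C)CCCNC(=O)NNC(=O)NC(CO)(CO)CO)c2ncccc2c1`, differs from compound 3 in one place: 2-hydroxy-1,1-bis(hydroxymethyl)ethyl in place of 2-hydroxyethyl on an amide-type nitrogen. Within the data shown here, none of the measured steps offers a readable size, so their only bearing is that every change so far around the amide-type nitrogen has left the value at the limit. The step expected in this assay is accordingly a step that the limit leaves unreadable from compound 3 to compound 4, which is to say none beyond the scatter, and most likely another limit rather than a number. Compound 4 is estimated in this assay at 300000 nM, within a range from 100000 nM to 1000000 nM.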

Compound 4, half-maximal inhibitory concentration: > 250000 nM
Compound 4: a limit, no number (the forecaster's own chance of this, stated with the estimate: 85%); the middle value is on the limit's open side.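

In this assay compound 4 gives only a limit, > 250000 nM. The steps to compound 4 from compound 1, compound 2 and compound 3 cannot be read, because all four compounds sit at one limit: the limit of > 250000 nM in this assay, at which 4 of the 4 values shown sit.

The compounds shown leave open whether any of these changes on the shared core alters inhibition at all, with no number among them.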